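The source may hold more compounds than are shown below. What is called first, only, known or untested is meant among the compounds shown, and "the series" means these compounds.

Measured in an ADME assay on HepG2 cells (Homo sapiens) for cytotoxicity, read by MTT assay, with a stated time of 72 h; on this read-out higher numbers stand for lower toxicity in this test and lower numbers for higher toxicity in this test:
- Compound 1 `CS(=O)(=O)Cc1nc2c(Sc3ccc(Cl)cc3)cc(Cl)cn2c1[N+](=O)[O-]`: > 31200 nM, a limit
- Compound 2 `O=[N+]([O-])c1c(CS(=O)(=O)c2ccccc2)nc2c(Nc3ccc(Cl)cc3)cc(Cl)cn12`: > 3900 nM, a limit
- Compound 3 `O=[N+]([O-])c1c(CS(=O)(=O)c2ccccc2)nc2c([Se]c3ccc(Cl)cc3)cc(Cl)cn12`: > 7800 nM, a limit

None of these three results is an exact number. Compound 3 stands only at its limit of > 7800 nM. Compound 4 `O=[N+]([O-])c1c(CS(=O)(=O)c2ccccc2)nc2c(Nc3ccccc3)cc(Cl)cn12` differs from compound 3 at one place: a group of 7 heavy atoms (6 carbon, 1 nitrogen; one six-membered aromatic ring of carbon only) in place of a group of 8 heavy atoms (6 carbon, 1 chlorine, 1 selenium; one six-membered aromatic ring of carbon only), on an aromatic carbon. Within the data shown here, the one measured step that bears on this change is a step that the two limits leave unreadable from compound 2 to compound 3. Its size cannot be read, so it offers no measured size or direction to carry over. A step beyond the usual scatter is therefore not expected in this assay. The estimate amounts to an expected step that the limit leaves unreadable from compound 3 to compound 4. Compound 4 is expected near 10000 nM, with an estimated range of 3900 nM to 32000 nM.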

Compound 4, half-maximal cytotoxic concentration: > 3900 nM
Compound 4: only a limit was reported; the forecaster's own chance of this, stated with the estimate: 75%; the middle value is on the limit's open side.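

In this assay compound 4, like compound 2 and compound 3, gave only a limit, so neither step to compound 4 can be read. The compounds shown leave open whether either change alters the cytotoxic concentration at all.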